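The source may hold more compounds than are shown below. What is called first, only, known or untested is meant among the compounds shown, and "the series" means these compounds.

Compound 1 `O/N=C(\CCN1CCN(c2ccccn2)CC1)c1ccccc1Cl` gives 74% in a functional assay on HEK293 cells with D(4) dopamine receptor (Homo sapiens) as the target, read by FLIPR; on this read-out lower numbers stand for smaller maximal responses and higher numbers for larger maximal responses.
Compound 2 `O/N=C(/CCN1CCN(c2ccccn2)CC1)c1ccccc1Cl` gives 64% in this assay.
Compound 3 `CO/N=C(\CCN1CCN(c2ccccn2)CC1)c1ccccc1Cl` gives 79% in this assay.

Compound 3 stands highest of the three numbers. Its nearest neighbour is compound 1, reached through a number 5 percentage points higher from compound 1 to compound 3 (within the scatter), a gap within the scatter. Compound 2 lies furthest away: compound 3 gives 79%, while compound 2 gives 64%, a gap beyond the scatter.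

The unmeasured compound 4 `CO/N=C(/CCN1CCN(c2ccccn2)CC1)c1ccccc1Cl` differs from compound 3 as follows: the two compounds have the same atoms and bonds and differ only in configuration as drawn: 1 of 1 stereo elements differ; a double bond is drawn E in compound 3 and Z in compound 4. For the measured compounds named here, the one measured step that bears on this is a number 10 percentage points lower from compound 1 to compound 2 (within the scatter), which rests on (the fact that compounds 1 and 2 differ only in the configuration as drawn). That step was small and within the scatter. By the same kind of change, compound 4 is therefore expected to sit somewhat below compound 3, with a step of about a number 10 percentage points lower from compound 3 to compound 4 (within the scatter), likely within the scatter. In this assay compound 4 is estimated at 69%, with a range from 55% to 83%.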

Compound 4, largest response reached (reported as efficacy), in percent of the reference or control that the assay uses: 73%
Compound 4: middle estimate off by 4 percentage points, on the low side, and the stated range covers the measured number.
By their numbers in this assay, from the lowest: compounds 2, 4, 1 and 3 (each within the scatter of the next, the first and the last beyond it).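

In this assay, the change of the double bond from E to Z now reads on the methyl ether as well as on the free oxime, as a number 6 percentage points lower from compound 3 to compound 4 (within the scatter), beside a number 10 percentage points lower from compound 1 to compound 2 (within the scatter) on the earlier pair; on both pairs the step stays within the scatter. Methyl in place of hydrogen on the oxygen can now also be read on the Z pair, as a number 9 percentage points higher from compound 2 to compound 4 (within the scatter). That change thus has two readings, and they agree: the same change on two cores in this assay, a number 5 percentage points higher (within the scatter) from compound 1 to compound 3 and a number 9 percentage points higher (within the scatter) from compound 2 to compound 4, 4 percentage points apart, within the scatter of two such steps.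

What the compounds shown leave open is whether the response stays in this range with a larger group on that oxygen, such as ethyl or benzyl. They also do not tell what a fluorine or a methoxy group in place of the chlorine would do.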